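This account rests on a few compounds, and the source may have more. Where it says the series, first, only, none or still open, it means among the compounds named here.

Measured so far in a functional assay on MIA PaCa-2 cells (Homo sapiens) for inhibition, read by MTT assay, with a stated time of 4 days; a higher number here means a weaker inhibitor, a lower number a stronger inhibitor:
Compound 1 `COc1cc(NC(C)CCCNC(=O)NCCNC(c2ccccc2)(c2ccccc2)c2ccccc2)c2ncccc2c1` gives 40000 nM.
Compound 2 `COc1cc(NC(C)CCCNC(=O)NNC(=O)N(CCO)CCO)c2ncccc2c1` gives only a limit, > 250000 nM.
Compound 3 `COc1cc(NC(C)CCCNC(=O)Nc2ccc(Cl)c(C(F)(F)F)c2)c2ncccc2c1` gives 4000 nM.

Compound 2 stands at the limit of this assay, (the limit of > 250000 nM in this assay, at which 1 of the 3 values shown sits); its value is a limit and not a number, and it is the only one of the three to sit there. Compound 4 `COc1cc(NC(C)CCCNC(=O)NNC(=O)Nc2ccc(Cl)c(C(F)(F)F)c2)c2ncccc2c1` is the next step from compound 2: (4-chloro-3-(trifluoromethyl)phenyl)amino in place of bis(2-hydroxyethyl)amino on a carbonyl carbon. Among the compounds with values here, the one measured step that bears on this is an at least 62-fold lower number from compound 2 to compound 3 (1.79 log units; beyond the scatter), in which the bis(2-hydroxyethyl)carbamoyl-carrying group gave way to the 4-chloro-3-(trifluoromethyl)phenyl group, though there the change sits on an amide-type nitrogen rather than on a carbonyl carbon, so compound 3 is not the same structure as compound 4. A large drop in the number in this assay is therefore expected, an at least 12-fold lower number from compound 2 to compound 4 (1.09 log units; beyond the scatter), though the difference in where the change sits leaves its size uncertain. For compound 4 the estimate in this assay is 20000 nM, with a range from 4000 nM to 120000 nM.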

Compound 4, half-maximal inhibitory concentration: 18000 nM
For compound 4 the middle estimate is 1.1-fold (0.05 log units) above the measured one; low and high end bracket the measured number.
By their numbers in this assay, from the lowest: compound 3; then compound 4; then compound 1. At a limit, above all of these: compound 2.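

In this assay, the gain from the 4-chloro-3-(trifluoromethyl)phenyl group also appears when it enters as (4-chloro-3-(trifluoromethyl)phenyl)amino on the carbonyl carbon, with the amide-type nitrogen on that carbonyl kept in place: an at least 13-fold lower number from compound 2 to compound 4 (1.14 log units; beyond the scatter). The size of this step is only a bound, as compound 2 has a limit and not a number: the limit of > 250000 nM in this assay, at which 1 of the 4 values shown sits.

With the same aryl group, compound 3 gives 4000 nM and compound 4 gives 18000 nM, so the aryl group alone does not fix the value in this assay; the link that carries it also goes with a different printed number.

On these data alone, whether the gain rests on the ring itself or on its chlorine and trifluoromethyl substituents remains open. A plain phenylamino group on the same carbonyl carbon would separate the two.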